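Methylpyridinyl for chloropyridinyl on the amine: working notes

The source may hold more compounds than are shown below. What is called first, only, known or untested is meant among the compounds shown, and "the series" means these compounds.

Measured so far:
compound 1 `Cc1cccc(NC[C@@H]2CC3(CC3)CN2C(=O)c2nc(C)sc2-c2ccccc2)n1` gives 7.3 in a functional assay on CHO cells for antagonist activity at Orexin/Hypocretin receptor type 1 (Homo sapiens), read by FLIPR and calcium flux; a lower number here means a less potent compound, a higher number a more potent compound, by a factor of ten per unit of this negative logarithm
compound 2 `Cc1ccc(-n2nccn2)c(C(=O)N2CC3(CC3)C[C@H]2CNc2ccc(Cl)cn2)c1` gives 8.1 in this assay
compound 3 `Cc1nc(C(=O)N2CC3(CC3)C[C@H]2CNc2ccc(Cl)cn2)c(-c2ccccc2)s1` gives 8.3 in this assay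

Compound 2 and compound 3 carry the same 5-chloropyridin-2-yl amine on different cores; the difference between the two cores is not broken down here. In this assay the values of compound 2 and compound 3 lie within the scatter of each other. The change 6-methylpyridin-2-yl in place of 5-chloropyridin-2-yl on an amine nitrogen gives a number 1.00 log units lower from compound 3 to compound 1 (beyond the scatter). Compound 4 `Cc1ccc(-n2nccn2)c(C(=O)N2CC3(CC3)C[C@H]2CNc2cccc(C)n2)c1` applies the same change to compound 2: 6-methylpyridin-2-yl in place of 5-chloropyridin-2-yl on an amine nitrogen, at the same place as before. Among the measured compounds shown here, for compound 4 a step of a number 1.00 log units lower from compound 2 to compound 4 (beyond the scatter) is expected, resting on the single measured precedent a number 1.00 log units lower from compound 3 to compound 1 (beyond the scatter). For the measured compounds named here, with only one precedent the range is kept wide. Compound 4 is therefore estimated at 7.1 in this assay, expected between 6.6 and 7.6.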

Compound 4, negative logarithm of the antagonist equilibrium constant: 7.1
Estimate against measurement, compound 4: no gap at the digits printed; the range from low to high includes it.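

In this assay, 6-methylpyridin-2-yl in place of 5-chloropyridin-2-yl on the amine nitrogen gives a number 1.00 log units lower from compound 2 to compound 4 (beyond the scatter), and this agrees with the earlier step on the other core: the same change on two cores in this assay, a number 1.00 log units lower (beyond the scatter) from compound 3 to compound 1 and a number 1.00 log units lower (beyond the scatter) from compound 2 to compound 4, 0.00 log units apart, within the scatter of two such steps. On these two cores, the change therefore carries over with its size unchanged. This rests on two pairs only and does not show that the same step would hold on any further core, nor does it explain why the step arises.

The chlorine leaves and the methyl enters in the same change, so their separate contributions remain unresolved. On these data alone, a plain pyridin-2-yl or a phenyl ring on the same amine nitrogen remains open on both cores.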